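The source may report more compounds than this note shows. Statements on the series, on what has been measured and on what is new or still open speak of the compounds shown alone.

Measured so far:
Compound 1 `c1ccc(-n2cc3cnc(-c4ccsc4)cc3n2)cc1` gives 9800 nM in a functional assay on MCF7 cells (Homo sapiens) for inhibition, read by fluorescence, with a stated time of 72 h; a lower number here means a stronger inhibitor of growth, a higher number a weaker inhibitor of growth.
Compound 3 `CC(C)c1nc(-c2ccccc2)cc2nn(-c3ccccc3)cc12` gives 91000 nM.
Compound 2 `Cc1nc(CCO)cc2nn(-c3ccccc3)cc12` reaches only a limit of the assay, > 100000 nM.

That limit is the limit of > 100000 nM in this assay, at which 1 of the 3 values shown sits, so compound 2 stands at the weak end of what this assay can report, without a number of its own. Compound 4 `Cc1nc(-c2ccsc2)cc2nn(-c3ccccc3)cc12` has not been measured. It differs from compound 2 in one place: thiophen-3-yl in place of 2-hydroxyethyl on an aromatic carbon. Going by the values given here, no measured pair differs in just one spot, so the size of this step has no direct precedent. Compound 1 carries the same thiophen-3-yl group and gives 9800 nM, well inside the measurable range. The step from compound 2 to compound 4 is therefore expected to be an at least 5.0-fold lower number from compound 2 to compound 4 (0.69 log units; beyond the scatter), towards stronger inhibition. Compound 4 is estimated to give 20000 nM, within 5000 nM to 80000 nM.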

Compound 4, concentration for 50% growth inhibition: 22200 nM
Compound 4: the middle estimate sits 1.1-fold (0.05 log units) below what was measured, and the stated range covers the measured number.
By their numbers in this assay, from the lowest: compound 1; then compound 4; then compound 3. At a limit, above all of these: compound 2.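

Compound 2 stands at a limit, not at a number: the limit of > 100000 nM in this assay, at which 1 of the 4 values shown sits.

In this assay, thiophen-3-yl in place of 2-hydroxyethyl on this aromatic carbon next to the ring nitrogen gives an at least 4.5-fold lower number from compound 2 to compound 4 (0.65 log units; beyond the scatter), so the true size of the step could be larger. Methyl in place of hydrogen gives a 2.3-fold higher number from compound 1 to compound 4 (0.36 log units; beyond the scatter), so with thiophen-3-yl in place, the value stays measurable with or without the methyl group.

On these data alone, what an amine, a carboxylic acid or a longer carbon chain would do on this carbon stays open. So does whether the step comes from the thiophen-3-yl ring arriving or from 2-hydroxyethyl leaving.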